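Amide variants near the limit in HepG2 cells

This account rests on a few compounds, and the source may have more. Where it says the series, first, only, none or still open, it means among the compounds named here.

Measured in a functional assay on HepG2 cells (Homo sapiens) for antiproliferative activity, read by MTT assay, with a stated time of 72 h; on this read-out higher numbers stand for weaker inhibition and lower numbers for stronger inhibition:
- compound 1 `Cc1noc(C)c1-c1nn(Cc2ccc(C(=O)NC3CC3)cc2)c(=O)c2ccccc12`: > 100000 nM (a limit)
- compound 2 `Cc1noc(C)c1-c1nn(Cc2ccc(C(=O)N3CCCCC3)cc2)c(=O)c2ccccc12`: 97300 nM
- compound 3 `Cc1noc(C)c1-c1nn(Cc2ccc(C(=O)NC3CCN(C)CC3)cc2)c(=O)c2ccccc12`: > 100000 nM (a limit)

Compound 3 has no number, only a limit, and it shares that position with one other compound: the limit of > 100000 nM in this assay, at which 2 of the 3 values shown sit. Compound 4 `Cc1noc(C)c1-c1nn(Cc2ccc(C(=O)NC3CCCC3)cc2)c(=O)c2ccccc12` carries cyclopentyl in place of 1-methylpiperidin-4-yl on an amide-type nitrogen. Among the measured compounds shown here, two measured steps bear on this change: an at least 1.0-fold lower number from compound 1 to compound 2 (0.01 log units; that floor lies within the scatter) and an at least 1.0-fold higher number from compound 2 to compound 3 (0.01 log units; that floor lies within the scatter). Each sets only a floor within the scatter. The third, a step that the two limits leave unreadable from compound 1 to compound 3, gives no size. No step beyond the scatter is therefore expected in this assay, and the estimated step is a number no higher from compound 3 to compound 4 (the limit leaves the size open). The expected value for compound 4 is 100000 nM, with an estimated range of 50000 nM to 200000 nM.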

Compound 4, half-maximal inhibitory concentration: > 100000 nM
Compound 4 was reported as a limit; the forecaster's own chance of this, stated with the estimate: 70%; the middle value lies on the limit itself.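

In this assay compound 4 gives > 100000 nM, a limit. On the amide-type nitrogen, neither the ring of carbon only in cyclopentyl nor the ring with a hetero atom in 1-methylpiperidin-4-yl yields a number: the limit of > 100000 nM in this assay, at which 3 of the 4 values shown sit. Against the piperidin-1-yl amide, the result is an at least 1.0-fold higher number from compound 2 to compound 4 (0.01 log units; that floor lies within the scatter), while the steps to compound 4 from compound 1 and compound 3 cannot be read.

Still open, as far as these compounds go, is whether an open alkyl chain or a primary amine on the amide-type nitrogen would give a value clear of the limit. A carboxylic acid in place of the amide is equally untested among the compounds shown.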